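The compounds below may be only part of what the source reports. "The series", "measured", "known", "first", "only" and "open" are said of these compounds alone.

Compound 1, `O[C@@H]1Cc2cc(Cl)ccc2N[C@H](c2cccs2)C1`, gives 164000 nM in an ADME assay on Vero cells (Chlorocebus sabaeus) for cytotoxicity; on this read-out lower numbers stand for higher toxicity in this test and higher numbers for lower toxicity in this test.
Compound 2, `Cc1ccsc1[C@@H]1C[C@H](O)Cc2cc(Cl)ccc2N1`, gives 200000 nM in this assay.
Compound 3, `O[C@@H]1Cc2cc(OC(F)(F)F)ccc2N[C@H](c2ccco2)C1`, gives 166000 nM in this assay.

Compound 4, `Cc1ccc([C@@H]2C[C@H](O)Cc3cc(OC(F)(F)F)ccc3N2)o1`, has not yet been measured in this assay. It comes from compound 3 by methyl in place of hydrogen on an aromatic carbon. The same kind of change has already been made once, from compound 1 to compound 2, as methyl in place of hydrogen on an aromatic carbon; there it gave a 1.2-fold higher number from compound 1 to compound 2 (0.09 log units; within the scatter). The surroundings of the two changes differ: in compound 2 the methyl sits on a ring with one sulfur, next to the ring atom that bears a large group and two ring bonds from the ring sulfur, whereas in compound 4 it sits on a ring with one oxygen, next to the ring oxygen and two ring bonds from the ring atom that bears a large group. The difference between the cores of compound 1 and compound 3 is not broken down here; their values in this assay lie within the scatter of each other.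

Because the earlier step of a 1.2-fold higher number from compound 1 to compound 2 (0.09 log units; within the scatter) stayed within the scatter, compound 4 is expected to show a step of a 1.1-fold higher number from compound 3 to compound 4 (0.06 log units; within the scatter) in this assay. Compound 4 is therefore estimated at 190000 nM, between 120000 nM and 300000 nM.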

Compound 4, half-maximal cytotoxic concentration: 82100 nM
Compound 4: middle estimate off by 2.3-fold (0.36 log units), on the high side; measured number outside the range, below it.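

In this assay, the change from furan-2-yl to 5-methylfuran-2-yl gave a 2.0-fold lower number from compound 3 to compound 4 (0.31 log units; beyond the scatter), a modest step that lies beyond the scatter. Set beside the same change on the other core, the two steps cannot be told apart: the same change on two cores in this assay, a 1.2-fold higher number (0.09 log units; within the scatter) from compound 1 to compound 2 and a 2.0-fold lower number (0.31 log units; beyond the scatter) from compound 3 to compound 4, 2.5-fold (0.39 log units) apart, within the scatter of two such steps. Among the compounds shown here, the data therefore do not show that methyl in place of hydrogen behaves differently on the two cores, yet they do not establish that it carries over unchanged either, as each core supplies only a single pair and the two pairs also differ in the ring that bears the methyl.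

The compounds shown leave open whether the lower number of compound 4 would recur with an ethyl group, a longer chain or an amine in the same place on the furan ring. They also leave open how much of any difference between the two steps belongs to the ring and how much to the rest of the core.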